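A few compounds are considered here, and "the series" means these few. Any claim that something is new, unique, unknown or untested is made for them only; others in the source may bear on it.

Measured so far in a physicochemical assay for solubility, in phosphate buffer, with a stated time of 18 h; a lower number here means a less soluble compound, a higher number a more soluble compound:
Compound 1 `CC(C)(C)c1nc(-c2ccccc2)c2c(N)c(C#N)c(N)nc2n1` gives 4000 nM
Compound 2 `CC(C)(C)c1nc(-c2ccc(C(=O)O)s2)c2c(N)c(C#N)c(N)nc2n1` gives > 1000000 nM (a limit of the assay)

Compound 2 stands at > 1000000 nM, which is a limit of the assay and not a number. The account now moves to compound 3 `CC(C)(C)c1nc(-c2ncc[nH]2)c2c(N)c(C#N)c(N)nc2n1`, which has 1H-imidazol-2-yl in place of 5-carboxythiophen-2-yl on an aromatic carbon. Among the measured compounds shown here, only one measured step bears on this change. It is an at least 250-fold higher number from compound 1 to compound 2 (2.39 log units; beyond the scatter), a large step that came with 5-carboxythiophen-2-yl in place of phenyl on that same carbon. Compound 3 gives up the group that entered in that step, and compound 1 , which also lacks it, gives 4000 nM. For the measured compounds named here, no measurement yet shows what 1H-imidazol-2-yl does in this assay, so compound 1 serves only as a rough anchor. A large step downward is therefore expected, with much of the rise seen for compound 2 lost. The expected change is an at least 66-fold lower number from compound 2 to compound 3 (1.82 log units; beyond the scatter), and its size is only an estimate given the limit at its starting point. For compound 3 the estimated value is 15000 nM, with an expected range from 2500 nM to 100000 nM.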

Compound 3, solubility: < 1000 nM
Compound 3 ended at the assay's limit; the forecaster's own chance of this, stated with the estimate: 3%; middle value at least 15-fold (1.17 log units) away from the limit.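

In this assay compound 3 gives < 1000 nM, which is a limit of the assay and not a number: the limit of < 1000 nM in this assay, at which 1 of the 3 values shown sits.

The earlier compounds shown here showed only a rise on this aromatic carbon, whereas 1H-imidazol-2-yl shows that the read-out can also fall well short of the level reached with 5-carboxythiophen-2-yl, with an at least 1000-fold lower number from compound 2 to compound 3 (3.00 log units; beyond the scatter), and fall short of the level with phenyl, with an at least 4.0-fold lower number from compound 1 to compound 3 (0.60 log units; beyond the scatter). Both 5-carboxythiophen-2-yl and 1H-imidazol-2-yl hold one five-membered aromatic ring on the same carbon of the shared core, so the presence of such a ring at this position does not by itself settle the read-out in this assay.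

The compounds shown leave open how much of the high number of compound 2 belongs to the carboxylic acid and how much to the sulfur-containing ring, a question that a plain thiophene or a phenyl ring bearing a carboxylic acid would address. Also open, as far as these compounds go, is how far the read-out lies beyond the limit of compound 3, and what an amine on the five-membered ring would do at this position.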